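Swapping a Furan Arm for a Phenyl Arm

A few compounds are considered here, and "the series" means these few. Any claim that something is new, unique, unknown or untested is made for them only; others in the source may bear on it.

Of the compounds shown here, two have been tested in a functional assay on G-361 cells (Homo sapiens) for cytotoxicity, read by sulforhodamine B assay; a higher number here means that more compound is tolerated, a lower number that less compound is tolerated. Compound 1 `CCCNc1ncnc2c1cnn2-c1ccccc1` reaches only the limit of > 100000 nM, so no number is known for it. Compound 2 `Cc1nc(NCc2ccco2)c2cnn(-c3ccccc3)c2n1` also reaches only the limit of > 100000 nM. Compound 2 therefore stands exactly where every value recorded so far sits, namely at the limit of > 100000 nM in this assay, at which 2 of the 2 values shown sit; neither compound has a true number, only a limit.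

Compound 3 `Cc1nc(NCc2ccccc2)c2cnn(-c3ccccc3)c2n1` differs from compound 2 in a single place: phenyl in place of furan-2-yl on a saturated chain carbon bound to a nitrogen on an aromatic ring. Put simply, the (furan-2-yl)methyl arm on the amine becomes a benzyl arm.

For the measured compounds named here, no step between measured compounds exists, so nothing measured says how large a change of this kind might be in this assay. Since both known compounds sit at the limit, the expectation for compound 3 is no step beyond the scatter, that is a number no higher from compound 2 to compound 3 (the limit leaves the size open). Compound 3 is therefore estimated at 100000 nM, with a range from 30000 nM to 300000 nM, and most likely the assay would again report only a limit rather than a number.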

Compound 3, concentration lethal to 50% of the cells: > 100000 nM
Compound 3: no number, only a limit; the forecaster's own chance of this, stated with the estimate: 85%; the middle value lies on the limit itself.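

In this assay compound 3 gives > 100000 nM, which is a limit and not a number. Compound 2 also gives only a limit, so no step can be read between compound 2 and compound 3. The whole set sits at one place: the limit of > 100000 nM in this assay, at which 3 of the 3 values shown sit. The compounds shown leave open what true lethal concentration any of them has.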